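Swapping bromo for methyl on the fused benzene ring

The source may hold more compounds than are shown below. What is called first, only, known or untested is meant among the compounds shown, and "the series" means these compounds.

Compound 1 `Fc1ccc(CNc2nc(Nc3cc(C4CC4)[nH]n3)c3ccccc3n2)c(F)c1`: 4.7 nM
Compound 2 `Fc1ccc(CNc2nc(Nc3cc(C4CC4)[nH]n3)c3cc(Br)ccc3n2)c(F)c1`: 120 nM

In an assay for inhibition of high affinity nerve growth factor receptor (Homo sapiens), read by HTRF, with a stated time of 30 min, in the presence of a further agent that is not named here (on this read-out lower numbers stand for stronger inhibition and higher numbers for weaker inhibition), compound 2 stands highest of the two numbers; its nearest neighbour is compound 1, and the step of a 26-fold higher number from compound 1 to compound 2 (1.41 log units; beyond the scatter) was large. Compound 3 `Cc1ccc2nc(NCc3ccc(F)cc3F)nc(Nc3cc(C4CC4)[nH]n3)c2c1` differs from compound 2 by methyl in place of bromo on an aromatic carbon. Among the measured compounds shown here, no measured step shows what methyl does at this place, so the only guide is that adding bromo there raised the number strongly. A partial return towards compound 1 is expected, so compound 3 is estimated at 40 nM (range 10 nM to 160 nM), a step of a 3.0-fold lower number from compound 2 to compound 3 (0.48 log units; beyond the scatter).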

Compound 3, half-maximal inhibitory concentration: 57 nM
The estimate for compound 3 lay 1.4-fold (0.15 log units) below the measured number, and the stated range covers the measured number.
By their numbers in this assay, from the lowest: compound 1; then compound 3; then compound 2.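

In this assay, methyl in place of hydrogen also weakens inhibition strongly (a 12-fold higher number from compound 1 to compound 3 (1.08 log units; beyond the scatter)), so the loss is not peculiar to bromo. Methyl in place of bromo gives back only a small part of that loss (a 2.1-fold lower number from compound 2 to compound 3 (0.32 log units; beyond the scatter)), and both substituted compounds remain far weaker than compound 1. Nothing available explains why either group weakens inhibition at this place.

From the compounds shown here alone, what fluoro, methoxy or an amine would do here remains open, as does whether any group at this place can keep the number close to that of compound 1.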